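The source may report more compounds than this note shows. Statements on the series, on what has been measured and on what is new or still open speak of the compounds shown alone.

Measured compounds:
compound 1 `CCCNC1=NS(=O)(=O)c2cccc(Cl)c2N1`, 180000 nM
compound 2 `CC(C)NC1=NS(=O)(=O)c2cccc(Cl)c2N1`, > 300000 nM
compound 3 `CCCNC1=NS(=O)(=O)c2cc(Cl)ccc2N1`, 55500 nM

In a functional assay on aorta (Rattus norvegicus) for inhibition (a higher number here means that more compound is needed for the effect, a lower number that less compound is needed), compound 1 gives 180000 nM. For compound 2 the value is a limit of the assay, not a number: in this assay compound 2 gives > 300000 nM. The change from compound 1 to compound 2 is isopropyl in place of propyl on an amine nitrogen, and it made an at least 1.6-fold higher number from compound 1 to compound 2 (0.22 log units; that floor lies within the scatter); how far it really reaches is hidden, because of the limit of > 300000 nM in this assay, at which 1 of the 3 values shown sits.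

Compound 3 stands lowest of the numbers in this assay with 55500 nM, its nearest neighbour being compound 1. The difference between the core of compound 1 and the core of compound 3 is not broken down here.

Compound 4 `CC(C)NC1=NS(=O)(=O)c2cc(Cl)ccc2N1` has not yet been measured. It differs from compound 3 by isopropyl in place of propyl on an amine nitrogen, the same change as from compound 1 to compound 2, at a place described in the same words. On the strength of the earlier step of an at least 1.6-fold higher number from compound 1 to compound 2 (0.22 log units; that floor lies within the scatter), the step in this assay is expected to be a 2.0-fold higher number from compound 3 to compound 4 (0.30 log units; within the scatter), a number on the higher side, though the earlier step is only a floor and lies within scatter. Compound 4 is therefore estimated at 110000 nM, with a likely span from 40000 nM to 300000 nM.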

Compound 4, half-maximal effective concentration: 36300 nM
For compound 4 the middle estimate is 3.0-fold (0.48 log units) above the measured one; measured number below the stated range.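

On the core of compound 3, isopropyl in place of propyl on the amine nitrogen gave in this assay a 1.5-fold lower number from compound 3 to compound 4 (0.18 log units; within the scatter), so this step alone shows no measurable effect of the change on that core. Set beside the step on the core of compound 1, it shows neither that the change carries over from one core to the other nor that it fails to do so: the same change on two cores in this assay, an at least 1.6-fold higher number (0.22 log units; that floor lies within the scatter) from compound 1 to compound 2 and a 1.5-fold lower number (0.18 log units; within the scatter) from compound 3 to compound 4; the limit leaves it open whether they differ Compound 2, with > 300000 nM, stands at a limit of the assay and not at a number, so the size of the step on the core of compound 1 stays unknown and only one of the two steps has a measured size: the limit of > 300000 nM in this assay, at which 1 of the 4 values shown sits.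

The compounds shown leave open whether a longer chain such as butyl, or a cyclopropyl group, on the amine nitrogen would give a step beyond the scatter on either core. They also leave open what a fluorine or a methyl group in place of the chlorine would do, with either propyl or isopropyl on that nitrogen.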